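The compounds below may be only part of what the source reports. "The series", "measured", "known", "first", "only" and "open" are said of these compounds alone.

Three measured compounds share one core and differ only in the groups attached to it. Compound 1 `Cc1cc(NC(=O)Cn2nnc(-c3ccccc3)n2)n(C2CCS(=O)(=O)C2)n1` gives 93% in an assay on HEK293 cells for activation of Kir3.1/Kir3.2 (Homo sapiens), read by thallium flux; a higher number here means a larger maximal response, a lower number a smaller maximal response. Compound 2 `CC1CC1c1cc(NC(=O)Cn2nnc(-c3ccccc3)n2)n(C2CCCCC2)n1` gives 78% in this assay, and compound 3 `Cc1cc(NC(=O)Cn2nnc(-c3cccc(Cl)c3)n2)n(C2CCCCC2)n1` gives 89% in this assay. Compound 3 stands close to compound 1, whose number lies within the usual scatter of this measurement, whereas the gap to compound 2 lies beyond the scatter, compound 2 giving the lower number.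

The next compound, compound 4 `COc1ccc(-c2nnn(CC(=O)Nc3cc(C)nn3C3CCCCC3)n2)cc1`, has not yet been measured. It differs from compound 3 in one place: 4-methoxyphenyl in place of 3-chlorophenyl on an aromatic carbon. Going by the values given here, no pair of measured compounds shows a step of this kind, so there is no direct guide for it. All three measured compounds give a large maximal response in this assay, and the change keeps a single six-membered aromatic ring of carbon only in the same place. The expected step is a number 4 percentage points lower from compound 3 to compound 4 (within the scatter), small and possibly none beyond the scatter. Compound 4 is therefore estimated to reach about 85% in this assay, with a likely range from 65% to 100%.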

Compound 4, largest response reached (Emax), in percent of the reference or control that the assay uses: 90%
Beside the measured number, compound 4's estimate is 5 percentage points below it; the range from low to high includes it.
By their numbers in this assay, from the lowest: compound 2; then compounds 3, 4 and 1 (each within the scatter of the next).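

Replacing 3-chlorophenyl with 4-methoxyphenyl on the aromatic carbon of the five-membered aromatic ring with 4 nitrogen gives, in this assay, a number 1 percentage points higher from compound 3 to compound 4 (within the scatter). Going by these compounds alone, this is the first direct view of this position, and it shows that the large maximal response survives a change of both the substituent on the six-membered ring and where it sits, even though the entering group carries a hydrogen-bond acceptor and the leaving group has none. No separate measurement bears on the reason for this result.

With both features changing in a single step, their separate contributions cannot be told apart. As far as these compounds go, it also remains open whether an amine or a carboxylic acid on this aromatic ring, or a butyl chain in its place, would keep a response this large.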